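Replacing Fluoro with Methylsulfanyl on the Active Biaryl Amide

The source may report more compounds than this note shows. Statements on the series, on what has been measured and on what is new or still open speak of the compounds shown alone.

Compound 1 `O=C(CCc1cccc2c1B(O)OC2)Nc1ccc(-c2ccccc2)cc1`: 13000 nM
Compound 2 `O=C(CCc1cccc2c1B(O)OC2)Nc1cccc(-c2cccc(F)c2)c1`: 460 nM

Of the compounds shown here, two have been measured in a functional assay on HCT-116 cells (Homo sapiens) for antiproliferative activity, read by MTT assay, with a stated time of 72 h; a lower number here means a stronger inhibitor, a higher number a weaker inhibitor. Compound 2 stands lowest at 460 nM, making it the stronger inhibitor of the pair. Compound 1 gives 13000 nM, and the gap between the two numbers lies well beyond the scatter.

Compound 3 `CSc1cccc(-c2cccc(NC(=O)CCc3cccc4c3B(O)OC4)c2)c1` is the next to be measured. It departs from compound 2 at one place, with methylsulfanyl in place of fluoro on an aromatic carbon, meta to a large group (methylsulfanyl in place of fluoro on an aromatic carbon). For the measured compounds named here, no measured pair shows a change at this place, so the expectation starts from compound 2 at 460 nM and remains loose. The estimated change, a 1.3-fold higher number from compound 2 to compound 3 (0.12 log units; within the scatter), is expected to stay within the scatter, with a slightly higher number if any. For compound 3 the expected value is 600 nM, with an estimated range of 200 nM to 1800 nM.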

Compound 3, half-maximal inhibitory concentration: 110 nM
Beside the measured number, compound 3's estimate is 5.5-fold (0.74 log units) above it; the measured number lies below the stated range.
By their numbers in this assay, from the lowest: compound 3; then compound 2; then compound 1.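

At this aromatic carbon, meta to a large group, methylsulfanyl in place of fluoro gives a 4.2-fold lower number from compound 2 to compound 3 (0.62 log units; beyond the scatter) in this assay. For the compounds shown here, this is the first measured change at this place, and it shows that the number responds to the group held there and that fluoro is not needed for activity in these cells. Nothing in the data given accounts for the step.

Only fluoro and methylsulfanyl are shown at this place, leaving open whether methoxy, with oxygen in place of sulfur, or a longer chain such as ethylsulfanyl would give a lower or a higher number. Also open, as far as these compounds go, is whether the step seen in this assay carries over to other cell lines.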